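Cytotoxicity notes on a flavonol benzyl ether series

The source may report more compounds than this note shows. Statements on the series, on what has been measured and on what is new or still open speak of the compounds shown alone.

Three benzyl ethers of the shared core have been measured in an ADME assay on Huh-5-2 cells (Homo sapiens) for cytotoxicity, read by WST assay, with a stated time of 3 days; on this read-out higher numbers stand for lower toxicity in this test and lower numbers for higher toxicity in this test. Compound 1 `Cc1cccc(COc2cc(O)c3c(=O)c(O)c(-c4ccccc4)oc3c2)c1` gives 35000 nM. Compound 2 `COc1cccc(COc2cc(O)c3c(=O)c(O)c(-c4ccccc4)oc3c2)c1` differs from compound 1 by methoxy in place of methyl on an aromatic carbon. In this assay compound 2 gives only a limit, > 100000 nM. The step is an at least 2.8-fold higher number from compound 1 to compound 2 (0.45 log units; beyond the scatter); here the limit of > 100000 nM in this assay, at which 1 of the 3 values shown sits, caps what can be read. Compound 3 `Cc1ccc(COc2cc(O)c3c(=O)c(O)c(-c4ccccc4)oc3c2)cc1` gives 88000 nM; the two cores differ by 4-methylphenyl in place of 3-methylphenyl on a saturated chain carbon bound to an oxygen on an aromatic ring, and the step is a 2.5-fold higher number from compound 1 to compound 3 (0.40 log units; beyond the scatter). Between compound 2 and compound 3 the step is an at least 1.1-fold lower number from compound 2 to compound 3 (0.05 log units; that floor lies within the scatter).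

Compound 4 `COc1ccc(COc2cc(O)c3c(=O)c(O)c(-c4ccccc4)oc3c2)cc1` is not yet measured; it differs from compound 3 by methoxy in place of methyl on an aromatic carbon. This is the same kind of change as from compound 1 to compound 2, but the place differs: there the methoxy sits meta to a large group, here para to a large group. Since compound 1 moved to compound 2 by an at least 2.8-fold higher number from compound 1 to compound 2 (0.45 log units; beyond the scatter), a step of comparable direction is expected from compound 3, a 2.0-fold higher number from compound 3 to compound 4 (0.31 log units; beyond the scatter), with a fair chance that only a limit is reported. Compound 4 is estimated at 180000 nM in this assay, within 70000 nM to 500000 nM.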

Compound 4, half-maximal cytotoxic concentration: > 100000 nM
Compound 4 gave a limit, no number; the forecaster's own chance of this, stated with the estimate: 70%; the middle value does not contradict the limit.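

Moved onto the core of compound 3, methoxy in place of methyl reads as an at least 1.1-fold higher number from compound 3 to compound 4 (0.05 log units; that floor lies within the scatter) in this assay, and that figure is only a floor set by the limit that compound 4 gives. The result does not go against the earlier step, but it does not show that the change carries over with the same size, nor that it carries over beyond the scatter at all: the same change on two cores in this assay, an at least 2.8-fold higher number (0.45 log units; beyond the scatter) from compound 1 to compound 2 and an at least 1.1-fold higher number (0.05 log units; that floor lies within the scatter) from compound 3 to compound 4; the limit leaves it open whether they differ

Against the 3-methylphenyl ether the reading is firmer, an at least 2.8-fold higher number from compound 1 to compound 4 (0.45 log units; beyond the scatter), while the step between the two methoxy compounds cannot be read.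

Left open is where the two methoxy compounds would really fall, as the read-out stops short of them: the limit of > 100000 nM in this assay, at which 2 of the 4 values shown sit.

Also open, from the compounds shown here alone, is how an amine or a carboxylic acid on the benzyl ring, or a longer chain in place of the benzyl group, would read in this assay.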